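Swapping 3-ethylphenyl for 2,5-dimethylphenyl on the sulfonamide

The source may hold more compounds than are shown below. What is called first, only, known or untested is meant among the compounds shown, and "the series" means these compounds.

Measured so far in a functional assay on CHO-TAX 5-6 cells (Cricetulus griseus) for antiproliferative activity, read by sulforhodamine B assay, with a stated time of 48 h; on this read-out lower numbers stand for stronger inhibition and higher numbers for weaker inhibition
compound 1 `O=C1NCCN1c1ccc(S(=O)(=O)Nc2ccc3[nH]ccc3c2)cc1` gives 640 nM
compound 2 `CCc1cccc(NS(=O)(=O)c2ccc(N3CCNC3=O)cc2)c1` gives 140 nM
compound 3 `O=C1NCCN1c1ccc(S(=O)(=O)Nc2cccc(Br)c2)cc1` gives 76 nM

Compound 2 (140 nM) lies well under compound 1 (640 nM). Among the measured compounds shown here, its one measured single-place step is a 1.8-fold lower number from compound 2 to compound 3 (0.27 log units; within the scatter) and this is a change of bromo in place of ethyl on an aromatic carbon.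

Compound 4 `Cc1ccc(C)c(NS(=O)(=O)c2ccc(N3CCNC3=O)cc2)c1` carries 2,5-dimethylphenyl in place of 3-ethylphenyl on a sulfonamide nitrogen and keeps the same atoms, joined differently. For the measured compounds named here, no measured compound carries the 2,5-dimethylphenyl group, so the evidence is indirect. Going by the values given here, the single relevant step stays small, which gives no ground to expect a large move in this assay here. The expected step is a 1.1-fold higher number from compound 2 to compound 4 (0.03 log units; within the scatter) and so none beyond the scatter. The upper end of the range leaves room towards compound 1 (640 nM), which has a different group on the sulfonamide nitrogen. Compound 4 is estimated at 150 nM (expected range 60 nM to 400 nM).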

Compound 4, half-maximal inhibitory concentration: 54 nM
Compound 4: the middle estimate sits 2.8-fold (0.44 log units) above what was measured; the whole stated range lies above it.
By their numbers in this assay, from the lowest: compounds 4, 3 and 2 (each within the scatter of the next, the first and the last beyond it); then compound 1.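

On the sulfonamide nitrogen, exchanging 3-ethylphenyl for 2,5-dimethylphenyl, two groups with the same heavy-atom count, gives a step in this assay that the earlier bromo change did not give: a 2.6-fold lower number from compound 2 to compound 4 (0.41 log units; beyond the scatter). How the carbons are arranged on this phenyl ring can therefore shift the read-out even when their number stays the same, whereas the comparison with 3-bromophenyl separates nothing: a 1.4-fold lower number from compound 3 to compound 4 (0.15 log units; within the scatter). No measured data bearing on the origin of the step from 3-ethylphenyl to 2,5-dimethylphenyl are available.

From the compounds shown here alone, it remains open whether a single methyl on this phenyl ring would be enough to give the same step, or whether both methyl groups are needed. Going by these compounds, the effect of chloro, methoxy, an amine or a carboxylic acid on this ring also remains open.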